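Moving the propenyl amide from compound 2 onto the ring position of compound 1

This account rests on a few compounds, and the source may have more. Where it says the series, first, only, none or still open, it means among the compounds named here.

Compound 1, `CCOC(=O)c1cc(-c2ccc(Oc3ccccc3)cc2)nn1Cc1cccc(NC(=O)CCl)c1`, in a functional assay on JeKo-1 cells (Homo sapiens) for inhibition, read by luminescence and CellTiter-Glo, with a stated time of 72 h (on this read-out lower numbers stand for stronger inhibition and higher numbers for weaker inhibition), gives 400 nM.
Compound 2, `C/C=C/C(=O)Nc1ccc(Cn2nc(-c3ccc(Oc4ccccc4)cc3)cc2C(=O)OCC)cc1`, in this assay gives 52500 nM.
Compound 3, `CCOC(=O)c1cc(-c2ccc(Oc3ccccc3)cc2)nn1Cc1ccc(NC(=O)CCl)cc1`, in this assay gives 400 nM.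

Compound 3 stands level with compound 1 and far from compound 2: no change at the digits printed from compound 1 to compound 3 (within the scatter), while a 130-fold lower number from compound 2 to compound 3 (2.12 log units; beyond the scatter). Compound 4, `C/C=C/C(=O)Nc1cccc(Cn2nc(-c3ccc(Oc4ccccc4)cc3)cc2C(=O)OCC)c1`, is reached from compound 3 by 3-(((prop-1-en-1-yl)carbonyl)amino)phenyl in place of 4-(((chloromethyl)carbonyl)amino)phenyl on a saturated chain carbon bound to an aromatic nitrogen. Among the measured compounds shown here, two measured steps bear on this. The step of no change at the digits printed from compound 1 to compound 3 (within the scatter) shows that the ring position of the amide made no difference for the chloromethyl series, and the step of a 130-fold lower number from compound 2 to compound 3 (2.12 log units; beyond the scatter) shows how large the change of the carbonyl substituent was. Compound 4 is therefore expected to show a large rise, a 130-fold higher number from compound 3 to compound 4 (2.10 log units; beyond the scatter), and to land near compound 2. Compound 4 is estimated at 50000 nM in this assay, in a range of 15000 nM to 150000 nM.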

Compound 4, half-maximal inhibitory concentration: 16700 nM
Compound 4: the middle estimate sits 3.0-fold (0.48 log units) above what was measured; the measured number falls inside the stated range.
By their numbers in this assay, from the lowest: compounds 1 and 3 (each within the scatter of the next); then compound 4; then compound 2.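

In this assay the place of the amide on the ring, which made no difference with chloromethyl, does count with prop-1-en-1-yl on the carbonyl carbon, with a 3.1-fold lower number from compound 2 to compound 4 (0.50 log units; beyond the scatter). The exchange of chloromethyl for prop-1-en-1-yl also raises the number on the second ring pattern, with a 42-fold higher number from compound 1 to compound 4 (1.62 log units; beyond the scatter), and the exchange together with the ring shift gives a 42-fold higher number from compound 3 to compound 4 (1.62 log units; beyond the scatter). The cost of this exchange therefore depends on where the amide sits: the same change on two cores in this assay, a 130-fold lower number (2.12 log units; beyond the scatter) from compound 2 to compound 3 and a 42-fold lower number (1.62 log units; beyond the scatter) from compound 4 to compound 1, 3.1-fold (0.50 log units) apart, beyond the scatter of two such steps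

The compounds shown leave open whether bromomethyl or ethenyl on the carbonyl carbon would follow chloromethyl or prop-1-en-1-yl.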